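Compound 4: (pentan-3-yl)amino replacing ethyl(propyl)amino

The source may report more compounds than this note shows. Statements on the series, on what has been measured and on what is new or still open speak of the compounds shown alone.

Among the measured compounds shown here, in an ADME assay on the whole organism for inhibition, with Echinochloa crus-galli var. formosensis as the target, with a stated time of 4 days (on this read-out higher numbers stand for weaker inhibition and lower numbers for stronger inhibition), compound 2 (`CCCN(CC)c1nc(Cl)nc(N[C@@H](C)c2ccccc2)n1`) gives 282 nM, the lowest of the three numbers so far. Compound 1 (`CCNc1nc(Cl)nc(N[C@H](C)c2ccccc2)n1`) gives 2690 nM and compound 3 (`CC(C)Nc1nc(Cl)nc(N[C@H](C)c2ccccc2)n1`) gives 2000 nM, both beyond the scatter from compound 2.

Compound 4 (`CCC(CC)Nc1nc(Cl)nc(N[C@@H](C)c2ccccc2)n1`) has (pentan-3-yl)amino in place of ethyl(propyl)amino on an aromatic carbon.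

For the measured compounds named here, the only measured step near this change is a 1.3-fold lower number from compound 1 to compound 3 (0.13 log units; within the scatter), so enlarging a chain on a nitrogen that keeps its hydrogen shows no effect there. Compound 4 shares that hydrogen with compound 1 and compound 3, but it shares its stereo configuration with compound 2. The data cannot separate these two differences. A moderate rise in this assay is therefore expected, stopping short of the number for compound 3 at 2000 nM.

The estimated step is a 2.3-fold higher number from compound 2 to compound 4 (0.36 log units; beyond the scatter).

For compound 4 the expected value is 650 nM, with an estimated range of 170 nM to 2500 nM.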

Compound 4, half-maximal inhibitory concentration: 23400 nM
Estimate against measurement, compound 4: 36-fold (1.56 log units) below; measured number outside the range, above it.
By their numbers in this assay, from the lowest: compound 2; then compounds 3 and 1 (each within the scatter of the next); then compound 4.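

In this assay the position between two ring nitrogen atoms proves sharply sensitive to the arrangement of its substituent: exchanging ethyl(propyl)amino for (pentan-3-yl)amino, with the same atoms joined differently, gives an 83-fold higher number from compound 2 to compound 4 (1.92 log units; beyond the scatter) and so weakens inhibition. The earlier step on a nitrogen that keeps its hydrogen lay within the scatter, so a large response at this position appears only with this pair. The entering group also brings a hydrogen-bond donor that the leaving group lacks, and no measurement available here separates that difference from the change in chain arrangement or explains the step.

Open, going by these compounds, is whether a diethylamino group at this position would fall nearer compound 2 or compound 4. Also open, on these data alone, is how much the stereo configuration contributes, since compound 1 and compound 3 carry the opposite configuration to compound 2 and compound 4.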